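Swapping One Aromatic Ring on a Shared Core

A few compounds are considered here, and "the series" means these few. Any claim that something is new, unique, unknown or untested is made for them only; others in the source may bear on it.

Three compounds with a shared core were tested in an in vitro functional assay on HEK285-7 cells for antagonist activity at prostaglandin D2 receptor 2 (Homo sapiens), read by BRET and beta-arrestin recruitment; on this read-out lower numbers stand for stronger inhibition and higher numbers for weaker inhibition. Compound 1 `CCC(c1ccccc1)c1nc(-c2ccc(Cl)cc2)c(CC(=O)O)s1` gives only a limit of the assay, > 100000 nM. Compound 2 `O=C(O)Cc1sc(C(c2ccccc2)c2ccc(F)cc2)nc1-c1ccc(Cl)cc1` gives 36 nM, and compound 3 `O=C(O)Cc1sc(C(c2ccc(F)cc2)c2ccc(F)cc2)nc1-c1ccc(Cl)cc1` gives 180 nM. The step of an at least 2700-fold lower number from compound 1 to compound 2 (3.44 log units; beyond the scatter) and the step of a 5.0-fold higher number from compound 2 to compound 3 (0.70 log units; beyond the scatter) both alter the saturated chain carbon bound to two aromatic carbons. Compound 3 thus stands highest of the two numbers, with compound 2 nearest. Compound 4 `Nc1cc(-c2nc(C(c3ccc(F)cc3)c3ccc(F)cc3)sc2CC(=O)O)cc(F)n1` differs from compound 3 elsewhere: 2-amino-6-fluoropyridin-4-yl in place of 4-chlorophenyl on an aromatic carbon. Neither measured step touches this place, so they give no direction; a step within or modestly beyond the scatter, either way, is plausible. Compound 4 is estimated at 300 nM, between 60 nM and 1500 nM, a step of a 1.7-fold higher number from compound 3 to compound 4 (0.22 log units; within the scatter).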

Compound 4, half-maximal inhibitory concentration: 1400 nM
For compound 4 the middle estimate is 4.7-fold (0.67 log units) below the measured one, and the stated range covers the measured number.
By their numbers in this assay, from the lowest: compound 2; then compound 3; then compound 4. At a limit, above all of these: compound 1.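

Setting 2-amino-6-fluoropyridin-4-yl in place of 4-chlorophenyl gives a 7.8-fold higher number from compound 3 to compound 4 (0.89 log units; beyond the scatter) and so shows that this position, untouched by the earlier steps, also shifts the number. The swap changes the ring, adds an amine and adds a fluorine all at once, so the step belongs to the whole group and cannot be divided among its parts. No measurement shown here accounts for this step.

A plain pyridin-4-yl, without the amine or the fluorine, could begin to separate those parts. Going by these compounds, whether the same swap has a similar effect on compound 2 also remains open.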